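Swapping 4-fluorophenyl for 3-chlorophenyl in compound 3

The source may report more compounds than this note shows. Statements on the series, on what has been measured and on what is new or still open speak of the compounds shown alone.

Values measured in a functional assay on PANC-1 cells (Homo sapiens) for inhibition, read by MTT assay, with a stated time of 24 h; on this read-out lower numbers stand for stronger inhibition and higher numbers for weaker inhibition

Compound 1 (`CC1(C)[C@H]2CC[C@]1(C)N(Cc1cn(-c3cccc(F)c3)nn1)C(=O)C2`) gives 220 nM
Compound 2 (`CC1(C)[C@H]2CC[C@]1(C)N(Cc1cn(-c3ccccc3Br)nn1)C(=O)C2`) gives 280 nM
Compound 3 (`CC1(C)[C@H]2CC[C@]1(C)N(Cc1cn(-c3ccc(F)cc3)nn1)C(=O)C2`) gives 110 nM

The data show a 2.0-fold lower number from compound 1 to compound 3 (0.30 log units; within the scatter) so these two compounds cannot be told apart. Compound 3 is clearly separated only from compound 2 (a 2.5-fold lower number from compound 2 to compound 3 (0.41 log units; beyond the scatter)). Compound 4 (`CC1(C)[C@H]2CC[C@]1(C)N(Cc1cn(-c3cccc(Cl)c3)nn1)C(=O)C2`) carries 3-chlorophenyl in place of 4-fluorophenyl on an aromatic nitrogen. For the measured compounds named here, no measured compound carries this group, so no step shows directly what trading fluorine for chlorine does. The closest guide is compound 1 (220 nM), which has 3-fluorophenyl. The change to a bromine-bearing ring was also small (a 1.3-fold higher number from compound 1 to compound 2 (0.10 log units; within the scatter)). A modest move toward a higher number is therefore expected in this assay, with no large jump, and the estimated step is small (a 1.8-fold higher number from compound 3 to compound 4 (0.26 log units; within the scatter)). Compound 4 is estimated at 200 nM ( expected range 90 nM to 450 nM).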

Compound 4, half-maximal inhibitory concentration: 260 nM
Beside the measured number, compound 4's estimate is 1.3-fold (0.11 log units) below it; the measured number falls inside the stated range.
By their numbers in this assay, from the lowest: compounds 3, 1, 4 and 2 (each within the scatter of the next, the first and the last beyond it).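

In this assay, chloro in place of fluoro on the same aromatic carbon makes no difference that can be told apart (a 1.2-fold higher number from compound 1 to compound 4 (0.07 log units; within the scatter)), and compound 4 also cannot be separated from the 2-bromophenyl compound (a 1.1-fold lower number from compound 2 to compound 4 (0.03 log units; within the scatter)). The 4-fluorophenyl compound, by contrast, now stands clear of two compounds rather than one (a 2.4-fold higher number from compound 3 to compound 4 (0.37 log units; beyond the scatter)), although compound 1 still lies within the scatter of compound 3. Nothing available here explains these differences.

Still open, going by these compounds, is how a 4-chlorophenyl group would compare with 4-fluorophenyl, a comparison that would separate the choice of halogen from its place on the ring. Also open, on these data alone, is what an unsubstituted phenyl, or a phenyl ring carrying a methoxy group or an amine, would do in this position.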